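This account rests on a few compounds, and the source may have more. Where it says the series, first, only, none or still open, it means among the compounds named here.

Working notes on the series. Compound 1, `Cn1nc(-c2ccccc2F)n(C)c1=S`, is the reference point. In a functional assay on the whole organism with Mus musculus as the target (on this read-out higher numbers stand for an effect only at larger amounts of compound and lower numbers for an effect already at smaller amounts), compound 1 gives 0.23 mg/kg, the lowest of the two numbers in hand. Compound 3, `Cn1nc(-c2ccc(F)cc2)n(C)c1=S`, also bears a fluoro on its aromatic ring; in this assay compound 3 gives 1 mg/kg, a higher number than compound 1 by a gap that lies beyond the usual scatter. Compound 2, `Cn1nc(-c2cccc3ccccc23)n(C)c1=S`, returns no number: in this assay compound 2 gives > 200 mg/kg, which is a limit of the assay (the limit of > 200 mg/kg in this assay, at which 1 of the 3 values shown sits). No two of the measured compounds differ in a single place, so no measured step can be read off and nothing about the effect of a single change is yet established.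

Compound 4, `Cn1nc(-c2ccccc2Cl)n(C)c1=S`, has not yet been run in this assay. Against compound 1 the change is chloro in place of fluoro on an aromatic carbon. One halogen is swapped for another, with the count of heavy atoms, donors, acceptors and charge unchanged, so the step expected is small: a 1.5-fold higher number from compound 1 to compound 4 (0.18 log units; within the scatter), within the scatter or at most a modest rise in dose. Compound 4 is therefore expected near 0.35 mg/kg, with a range from 0.1 mg/kg to 1.2 mg/kg.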

Compound 4, dose for half-maximal effect: 0.58 mg/kg
For compound 4 the middle estimate is 1.7-fold (0.22 log units) below the measured one; low and high end bracket the measured number.
By their numbers in this assay, from the lowest: compound 1; then compounds 4 and 3 (each within the scatter of the next). At a limit, above all of these: compound 2.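

In this assay, among these compounds, chloro in place of fluoro on an aromatic carbon, ortho to a group of 8 heavy atoms, gives a 2.5-fold higher number from compound 1 to compound 4 (0.40 log units; beyond the scatter) as the first single-place step. The position therefore responds to the identity of the halogen, even though the count of heavy atoms, hydrogen-bond donors, hydrogen-bond acceptors and net charge stays the same, and with chloro there compound 4 still gives 0.58 mg/kg as a measured number rather than a limit. Nothing measured in the series bears on why the number moves with this change.

The compounds shown leave open how this position responds to groups other than these two halogens, such as bromo, methyl, methoxy or an amine, and whether the same exchange made elsewhere on the six-membered aromatic ring gives a step of similar size. With a single step between compounds that differ in one place, no trend across the halogens, or across any other set of groups at this position, can yet be stated.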